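The source may hold more compounds than are shown below. What is called first, only, known or untested is meant among the compounds shown, and "the series" means these compounds.

In a functional assay on the whole organism (arterial blood) with Rattus norvegicus as the target (on this read-out lower numbers stand for an effect already at smaller amounts and higher numbers for an effect only at larger amounts of compound), compound 1 (`Cc1nc2cnccc2n1CC1CCN(C(=O)CC(C)(C)c2ccccc2)CC1`) gives 0.012 mg/kg and sits at the low end of the three numbers, together with compound 2 (`COC/C(=C\C(=O)N1CCC(Cn2c(C)nc3cnccc32)CC1)c1ccccc1`) at 0.022 mg/kg within the scatter of it. Compound 3 (`Cc1nc2cnccc2n1CC1CCN(C(=O)NC(c2ccccc2)c2ccccc2)CC1`) at 0.14 mg/kg lies clearly higher than both. Compound 4 (`Cc1nc2cnccc2n1CC1CCN(C(=O)CN(C)c2ccccc2)CC1`) carries methyl(phenyl)amino in place of 1-methyl-1-phenylethyl on a saturated chain carbon bound to a carbonyl carbon. Within the data shown here, no measured pair isolates such a change, so the expectation is tentative: a moderate rise in this assay beyond the scatter. The estimated change is a 5.0-fold higher number from compound 1 to compound 4 (0.70 log units; beyond the scatter) in the direction of a higher number. Compound 4 is expected at 0.06 mg/kg within a range from 0.015 mg/kg to 0.25 mg/kg on this estimate.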

Compound 4, dose for 50% inhibition: 0.31 mg/kg
Beside the measured number, compound 4's estimate is 5.2-fold (0.71 log units) below it; measured number outside the range, above it.
By their numbers in this assay, from the lowest: compounds 1 and 2 (each within the scatter of the next); then compound 3; then compound 4.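

In this assay the exchange of 1-methyl-1-phenylethyl for methyl(phenyl)amino on a saturated chain carbon bound to a carbonyl carbon gives a 26-fold higher number from compound 1 to compound 4 (1.41 log units; beyond the scatter) and marks this position as sensitive to the change. Both groups carry one six-membered aromatic ring of carbon only, so that ring alone does not keep the number low here. No available evidence accounts for the step.

The compounds shown leave open whether the rise goes with the entering nitrogen or with the lost carbon substituents. A benzyl or 1-phenylcyclopropyl group at this place could separate the two.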